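The compounds below may be only part of what the source reports. "The series", "measured", "known", "first", "only" and "open" are said of these compounds alone.

Compound 1 `COc1cc(-c2cc3cc(C4C(C#N)=C(N)OC5=C4C(=O)CCC5)cc(C)c3oc2=O)cc(OC)c1OC` is the starting point. For the measured compounds named here, in a functional assay on the whole organism (strain Swiss albino) with Mus musculus as the target, in the forced swim test, with a stated time of 5 min, at a dose of 0.5 mg/kg by the intraperitoneal route (on this read-out lower numbers stand for less inhibition and higher numbers for more inhibition at the one dose given (going by the name of the read-out)), compound 1 gives 5.22%, the lowest of the three numbers measured so far. Compound 3 `CCC(C)c1cc(C2C(C#N)=C(N)OC3=C2C(=O)CC(C)(C)C3)cc2cc(-c3ccc(OC)cc3)c(=O)oc12` gives 26.9%, the nearest value, and compound 2 `COc1cc(-c2cc3cc(C4C(C#N)=C(N)OC5=C4C(=O)CC(C)(C)C5)cc(C(C)C)c3oc2=O)cc(OC)c1OC` gives 29.2%; both of these stand beyond the usual scatter above compound 1, but each differs from compound 1 in more than one place, so no single change can be read from them. Compound 4 `COc1cc(-c2cc3cc(C4C(C#N)=C(N)OC5=C4C(=O)CCC5)cc(C(C)(C)C)c3oc2=O)cc(OC)c1OC` has not yet been measured. It differs from compound 1 by tert-butyl in place of methyl on an aromatic carbon. Going by the values given here, no directly comparable step is known, so the effect of this change is open. Compound 4 is expected to give 18%, in a range from 5% to 35%. That estimate means an expected step of a number 12.8 percentage points higher from compound 1 to compound 4 (beyond the scatter), modest and possibly within the scatter.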

Compound 4, a percentage reported as inhibition, in the whole organism at one dose (the size of the read-out at that dose, not a potency): 5.33%
Beside the measured number, compound 4's estimate is 12.7 percentage points above it; the range from low to high includes it.
By their numbers in this assay, from the lowest: compounds 1 and 4 (each within the scatter of the next); then compounds 3 and 2 (each within the scatter of the next).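

In this assay, tert-butyl in place of methyl on this aromatic carbon gives a number 0.1 percentage points higher from compound 1 to compound 4 (within the scatter), so compound 1 and compound 4 cannot be told apart. For the compounds shown here, this is the first reading of this position alone, as the earlier compounds each differed in more than one place, and it shows that the larger of these two carbon-only groups makes no difference beyond the scatter at this dose. Nothing available explains this result.

On these data alone, whether an amine or a carboxylic acid at this position would give a different number remains open. So does whether methyl and tert-butyl would still match at other doses.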